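Isobutyl in Place of Isopropyl on a Weak A2b Antagonist

The source may report more compounds than this note shows. Statements on the series, on what has been measured and on what is new or still open speak of the compounds shown alone.

Compound 1, `CCn1cnc2ncnc(N)c21`: > 30000 nM
Compound 2, `CC(C)n1cnc2c(N)ncnc21`: 16000 nM
Compound 3, `CCC(C)n1cnc2ncnc(N)c21`: > 30000 nM

Three compounds were tested in a functional assay on CHO cells for antagonist activity at adenosine receptor A2b (Homo sapiens); a lower number here means a stronger inhibitor, a higher number a weaker inhibitor. Compound 1 gives only a limit of the assay, > 30000 nM. Compound 3 likewise gives only a limit, > 30000 nM. For the measured compounds named here, compound 2 is the single compound with a number, 16000 nM, so it stands alone among the values shown.

The step from compound 1 to compound 3 is a step that the two limits leave unreadable from compound 1 to compound 3, which gives no usable size for a change in the chain on the ring nitrogen.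

Compound 4, `CC(C)Cn1cnc2c(N)ncnc21`, differs from compound 2 by isobutyl in place of isopropyl on an aromatic nitrogen. Going by the values given here, no measured step bears directly on this change, since the only measured step is unreadable and two of the three values sit at the limit (the limit of > 30000 nM in this assay, at which 2 of the 3 values shown sit). With compound 2 already weak and its neighbours at the limit, a step beyond the scatter in either direction cannot be expected with confidence, and it is estimated that compound 4 sits near compound 2, with the step from compound 2 to compound 4 estimated as a 1.3-fold higher number from compound 2 to compound 4 (0.10 log units; within the scatter). Compound 4 is therefore estimated at 20000 nM, within 7000 nM to 60000 nM.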

Compound 4, inhibition constant: > 30000 nM
Compound 4: no number, only a limit (the forecaster's own chance of this, stated with the estimate: 45%); at least 1.5-fold (0.17 log units) between middle value and limit.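

For the compounds shown here, replacing isopropyl with isobutyl on the aromatic nitrogen gives an at least 1.8-fold higher number from compound 2 to compound 4 (0.27 log units; that floor lies within the scatter), the first step at this position in this assay that can be read at all. That size is only a floor, as compound 4 gives a limit of the assay and not a number, so the data show a direction without showing how large the change is, and the floor alone does not set the two compounds apart beyond the usual scatter. Isopropyl therefore remains the only group on this nitrogen among the compounds shown that gives a number, and isobutyl joins the others at the ceiling of the assay: the limit of > 30000 nM in this assay, at which 3 of the 4 values shown sit.

Going by these compounds, how far compound 4 really lies from compound 2 stays open, as does whether the gap between them exceeds the scatter. Also open, on these data alone, is whether a cyclopropyl ring, a 2-hydroxyethyl chain or a benzyl group on this nitrogen would give a number at all, and whether any such group would come in lower than compound 2, which gives 16000 nM.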